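Bromo in place of nitro: expected cytotoxicity of compound 4

A few compounds are considered here, and "the series" means these few. Any claim that something is new, unique, unknown or untested is made for them only; others in the source may bear on it.

Compound 1 `CCC1(Cc2ccccc2)OS(=O)(=O)C=C1OCc1ccc(OC)cc1` — > 200000 nM
Compound 2 `CCC1(Cc2ccccc2)OS(=O)(=O)C=C1OCc1ccc(Cl)cc1` — > 200000 nM
Compound 3 `CCC1(Cc2ccccc2)OS(=O)(=O)C=C1OCc1ccc([N+](=O)[O-])cc1` — < 200000 nM

In an ADME assay on HEL cells (Homo sapiens) for cytotoxicity, with a stated time of 3 days (on this read-out higher numbers stand for lower toxicity in this test and lower numbers for higher toxicity in this test), compound 1 gives > 200000 nM, which is a limit of the assay rather than a number. Compound 2 likewise gives > 200000 nM, again a limit. Compound 3 stands apart: it gives < 200000 nM, also a limit, but one on the other side, so compound 3 is the only one of the three with a toxic concentration inside the measured window. The step of a number no higher from compound 2 to compound 3 (the limit leaves the size open) and the step of a number no higher from compound 1 to compound 3 (the limit leaves the size open) both point downward by an unreadable amount, as the limit of < 200000 nM in this assay, at which 1 of the 3 values shown sits, and the limit of > 200000 nM in this assay, at which 2 of the 3 values shown sit, set the edges that the numbers cannot cross.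

Compound 4 `CCC1(Cc2ccccc2)OS(=O)(=O)C=C1OCc1ccc(Br)cc1` differs from compound 3 by bromo in place of nitro on an aromatic carbon. Compound 4 thus carries bromo where compound 2 carries chloro, and the nitro that set compound 3 apart is gone. The bearing steps therefore suggest a move back toward the limit shared by compounds 1 and 2, upward, of a size the data leave open. For compound 4 the expected result in this assay is 250000 nM, in the range 100000 nM to 600000 nM, meaning an estimated step of an at least 1.2-fold higher number from compound 3 to compound 4 (0.09 log units; that floor lies within the scatter) upward, most likely reported only as a limit.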

Compound 4, half-maximal cytotoxic concentration: 171000 nM
Beside the measured number, compound 4's estimate is 1.5-fold (0.16 log units) above it, and the stated range covers the measured number.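

Going by these compounds alone, compound 4 is the first compound here with a true number rather than a limit, so with bromo on this aromatic carbon, para to a large group, the toxic concentration falls inside the measured window. In this assay, bromo in place of chloro gives an at least 1.1-fold lower number from compound 2 to compound 4 (0.06 log units; that floor lies within the scatter), and bromo in place of methoxy gives an at least 1.1-fold lower number from compound 1 to compound 4 (0.06 log units; that floor lies within the scatter), so neither floor is enough to set bromo apart from the other two groups. The steps that involve the nitro group cannot be read, because compound 3 is known only through a limit: the limit of < 200000 nM in this assay, at which 1 of the 4 values shown sits.

Still open, on these data alone, is whether compound 3 sits on one side of compound 4 or the other, and how far compounds 1 and 2, which are known only through limits, really lie from compound 4. Also open, as far as these compounds go, is how the toxic concentration would respond at this position to a group of a different kind, such as an amine or a carboxylic acid, in place of the bromo.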